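This account rests on a few compounds, and the source may have more. Where it says the series, first, only, none or still open, it means among the compounds named here.

Working notes on the series. Among the measured compounds shown here, in a physicochemical assay, with a stated time of 6 min (a higher number here means a weaker inhibitor, a lower number a stronger inhibitor), compound 1 (`O=C(Nc1ccc(F)cc1)Nc1nc(-c2cc3ccccc3o2)cs1`) gives 1130 nM as the only numeric reading so far. Compound 2 (`Cc1ccc(NC(=O)Nc2nc(-c3cc4cc(Br)ccc4o3)cs2)cc1`) reads > 200000 nM as its entry, which is a limit of the assay and not a number. For the measured compounds named here, compound 1 therefore has no numeric neighbour, and no measured step in one place is available.

Compound 3 (`COc1cccc(NC(=O)Nc2nc(-c3cc4ccccc4o3)cs2)c1`) keeps the core of compound 1 and carries 3-methoxyphenyl in place of 4-fluorophenyl on an amide-type nitrogen. Going by the values given here, the data contain no measured step that sizes this exchange. The expectation in this assay therefore favours neither direction and rests on compound 1 at 1130 nM as the single anchor. The estimated step of a 1.3-fold higher number from compound 1 to compound 3 (0.12 log units; within the scatter) is expected to stay within the usual scatter, although a single anchor leaves real uncertainty around that expectation. For compound 3 the expected value is 1500 nM with an estimated range from 300 nM to 8000 nM in this assay.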

Compound 3, half-maximal inhibitory concentration: 200 nM
The estimate for compound 3 lay 7.5-fold (0.88 log units) above the measured number; the whole stated range lies above it.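

Among the compounds shown here, with 3-methoxyphenyl in place of 4-fluorophenyl on the amide-type nitrogen and the core of compound 1 held fixed, this assay gives a 5.7-fold lower number from compound 1 to compound 3 (0.75 log units; beyond the scatter) and so shows for the first time that the number responds to a change at this position. The step belongs to the exchange as a whole: 4-fluorophenyl leaves with 0 hydrogen-bond acceptors and 3-methoxyphenyl enters with 1 hydrogen-bond acceptor, but a single pair cannot assign the shift to either the group that leaves or the group that enters. No measurement among those shown bears on the cause of this step.

The compounds shown leave open whether the step follows the methoxy group or the loss of the fluorine, and how this assay would read with an ethoxy group, a hydroxyl group or a dimethylamino group on the same phenyl ring. Compound 2 gives > 200000 nM as its entry, a limit of the assay and not a number, and it differs from compound 1 in more than one place, so it sizes no single change.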